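Benzylating a Ring Amine in a Sigma-1 Series

The compounds below may be only part of what the source reports. "The series", "measured", "known", "first", "only" and "open" are said of these compounds alone.

Measured compounds:
compound 1 `Cn1ncc2c1CCOC21CCN(N2CCC(c3ccccc3)CC2)CC1`, in an assay for displacement of a labelled ligand from Sigma non-opioid intracellular receptor 1 (Cavia porcellus), read by scintillation counting, with a stated time of 180 min (a lower number here means a stronger inhibitor, a higher number a weaker inhibitor), compound 1 gives 7 nM
compound 2 `COC1Cc2c(cnn2-c2ccccc2)C2(CCNCC2)O1`, compound 2 gives > 1000 nM

For compound 2 the value in this assay is a limit and not a number, at the limit of > 1000 nM in this assay, at which 1 of the 2 values shown sits, so compound 2 stands only as the weaker of the two values shown. Compound 3 `COc1ccc(CN2CCC3(CC2)OC(OC)Cc2c3cnn2-c2ccccc2)cc1` differs from compound 2 by 4-methoxybenzyl in place of hydrogen on an amine nitrogen in a ring. Among the measured compounds shown here, no step between measured compounds is available, so the expectation rests on the change alone: a gain in affinity well beyond the scatter is expected, an at least 33-fold lower number from compound 2 to compound 3 (1.52 log units; beyond the scatter). Compound 3 is accordingly estimated at 30 nM, within a range from 5 nM to 300 nM.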

Compound 3, inhibition constant: 1.5 nM
Estimate against measurement, compound 3: 20-fold (1.30 log units) above, and the stated range ends above it.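

Placing 4-methoxybenzyl on the amine nitrogen in the ring of the shared core gives an at least 660-fold lower number from compound 2 to compound 3 (2.82 log units; beyond the scatter) in this assay, so this nitrogen is a position where one substituent can have a large effect on affinity. The value for compound 2 is a limit and not a number, so the step gives only a minimum size: the limit of > 1000 nM in this assay, at which 1 of the 3 values shown sits.

The compounds shown leave open whether the gain needs the methoxy group, since a plain benzyl or a methyl on this nitrogen is not among them.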